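Cyano in place of trifluoromethoxy on compound 2

The compounds below may be only part of what the source reports. "The series", "measured", "known", "first", "only" and "open" are said of these compounds alone.

Within the data shown here, in a functional assay on VCaP cells (Homo sapiens) for antiproliferative activity, read by propidium iodide staining, with a stated time of 96 h (on this read-out higher numbers stand for weaker inhibition and lower numbers for stronger inhibition), only two compounds have numbers so far. Compound 1 (`CC(O)(COc1cccc(C(F)(F)F)c1)C(=O)Nc1ccc(S(F)(F)(F)(F)F)cc1`) gives 24700 nM and compound 2 (`CC(O)(COc1ccc(OC(F)(F)F)cc1)C(=O)Nc1ccc(S(F)(F)(F)(F)F)cc1`) gives 12800 nM as its value, so the two stand within the scatter of each other and compound 2 holds no separate place in the series. The next compound is compound 3 (`CC(O)(COc1ccc(C#N)cc1)C(=O)Nc1ccc(S(F)(F)(F)(F)F)cc1`), which carries cyano in place of trifluoromethoxy on an aromatic carbon, para to a large group (cyano in place of trifluoromethoxy on an aromatic carbon). Among the measured compounds shown here, no measured step covers this exchange, so the expectation rests on the two values and the structural change alone. A small step toward weaker inhibition in this assay is expected, not clearly beyond the scatter. The estimate gives a 1.6-fold higher number from compound 2 to compound 3 (0.19 log units; within the scatter) as the expected change. Compound 3 is estimated at 20000 nM in this assay, with an expected range (8000 nM to 50000 nM).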

Compound 3, half-maximal inhibitory concentration: 100000 nM
For compound 3 the middle estimate is 5.0-fold (0.70 log units) below the measured one; measured number outside the range, above it.
By their numbers in this assay, from the lowest: compounds 2 and 1 (each within the scatter of the next); then compound 3.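

Cyano in place of trifluoromethoxy on an aromatic carbon, para to a large group, gives the first change in this assay that lies beyond the scatter, with a 7.8-fold higher number from compound 2 to compound 3 (0.89 log units; beyond the scatter). The wider exchange of 4-cyanophenyl in place of 3-(trifluoromethyl)phenyl on an oxygen on a saturated carbon also lies beyond the scatter, with a 4.0-fold higher number from compound 1 to compound 3 (0.61 log units; beyond the scatter), so compound 3 stands apart from the other two compounds, which remain within the scatter of each other. No measurement on hand gives a reason for this rise.

The compounds shown do not separate the loss of trifluoromethoxy from the arrival of cyano as the source of the rise. A fluorine, a methoxy group or an amine on the same aromatic carbon would help to tell these two readings apart.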